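Methyl to Methoxy on a Fused Benzoxazine Core

The source may hold more compounds than are shown below. What is called first, only, known or untested is meant among the compounds shown, and "the series" means these compounds.

Measured compounds:
compound 1, `COc1cc2c(c(OC)c1)OCN(c1ccc3oc(-c4ccccc4)cc(=O)c3c1)C2`, 48.9%
compound 2, `Cc1cccc2c1OCN(c1ccc3oc(-c4ccccc4)cc(=O)c3c1)C2`, 30.4%

In a functional assay on MCF7 cells (Homo sapiens) for inhibition, read by MTT assay, with a stated time of 48 h, tested at 7.5 ug/mL (on this read-out higher numbers stand for more inhibition of growth at the one concentration tested and lower numbers for less inhibition of growth), compound 2 gives 30.4%, the lowest of the two numbers; the nearest, compound 1, is higher by a margin beyond the scatter. Compound 3, `COc1cccc2c1OCN(c1ccc3oc(-c4ccccc4)cc(=O)c3c1)C2`, differs from compound 2 by methoxy in place of methyl on an aromatic carbon. Going by the values given here, no step between measured compounds is available for this change. An increase of modest size, possibly at the edge of the scatter, is expected, because compound 1 with its methoxy groups gives 48.9%. Compound 3 is estimated at 38%, range 25% to 52%, a step of a number 7.6 percentage points higher from compound 2 to compound 3 (within the scatter).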

Compound 3, percent growth inhibition at one concentration: 32.5%
Compound 3: middle estimate off by 5.5 percentage points, on the high side; low and high end bracket the measured number.
By their numbers in this assay, from the lowest: compounds 2 and 3 (each within the scatter of the next); then compound 1.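

Read in this assay, methoxy in place of methyl on this aromatic carbon, ortho to a fused ring and meta to a fused ring, gives a number 2.1 percentage points higher from compound 2 to compound 3 (within the scatter) and so does not set the two compounds apart. Hydrogen in place of methoxy on an aromatic carbon gives a number 16.4 percentage points lower from compound 1 to compound 3 (beyond the scatter) and is the step beyond the scatter. Here the larger difference goes with the further methoxy of compound 1, not with the methyl-to-methoxy change.

On these data alone, whether an amine or a carboxylic acid on this carbon would shift the number remains open. Nothing measured here explains these numbers.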